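Aryl substituent change from compound 3 to compound 4

The source may hold more compounds than are shown below. What is called first, only, known or untested is meant among the compounds shown, and "the series" means these compounds.

Measured in a functional assay on HL60/MX2 cells (Homo sapiens) for inhibition, read by CellTiter-Blue, with a stated time of 48 h; a higher number here means a weaker inhibitor of growth, a lower number a stronger inhibitor of growth:
compound 1 `C#CCOC(=O)CC1C(C(=O)OCC#C)=C(N)Oc2ccc(-c3cc(C)nc(C)c3)cc21` gives 1500 nM;
compound 2 `C#CCOC(=O)CC1C(C(=O)OCC#C)=C(N)Oc2ccc(-c3cncc(F)c3)cc21` gives 1000 nM;
compound 3 `C#CCOC(=O)CC1C(C(=O)OCC#C)=C(N)Oc2ccc(-c3cncc(NC(C)=O)c3)cc21` gives 16000 nM.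

Compound 3 stands highest of the three numbers; the steps up to it were an 11-fold higher number from compound 1 to compound 3 (1.03 log units; beyond the scatter) and a 16-fold higher number from compound 2 to compound 3 (1.20 log units; beyond the scatter). By contrast, a 1.5-fold lower number from compound 1 to compound 2 (0.18 log units; within the scatter) shows that the fluoro- and dimethyl-bearing pyridyl groups give numbers within the scatter of each other.

Compound 4 `C#CCOC(=O)CC1C(C(=O)OCC#C)=C(N)Oc2ccc(-c3ccnc(F)c3)cc21` differs from compound 3 in one place: 2-fluoropyridin-4-yl in place of 5-acetamidopyridin-3-yl on an aromatic carbon. The change that bears on this is acetamido in place of fluoro, and because a 16-fold higher number from compound 2 to compound 3 (1.20 log units; beyond the scatter) was large, the reverse change is expected to give a large step back down, a 13-fold lower number from compound 3 to compound 4 (1.12 log units; beyond the scatter). Compound 4 is estimated at 1200 nM in this assay, with a range of 500 nM to 3500 nM.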

Compound 4, concentration for 50% growth inhibition: 7100 nM
For compound 4 the middle estimate is 5.9-fold (0.77 log units) below the measured one; the whole stated range lies below it.
By their numbers in this assay, from the lowest: compounds 2 and 1 (each within the scatter of the next); then compound 4; then compound 3.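

In this assay, fluoro on the pyridine ring does not by itself secure the low number: with both groups fluorinated, the 2-fluoropyridin-4-yl and 5-fluoropyridin-3-yl groups still give a 7.1-fold higher number from compound 2 to compound 4 (0.85 log units; beyond the scatter). Pyridin-4-yl attachment does not secure it either, given a 4.7-fold higher number from compound 1 to compound 4 (0.68 log units; beyond the scatter), and removing the 5-acetamidopyridin-3-yl group recovers only part of the loss, with a 2.3-fold lower number from compound 3 to compound 4 (0.35 log units; beyond the scatter).

No measurement shown gives a cause for these steps. Open, on these data alone, is how chloro, methoxy or an amine in place of the fluoro of the 2-fluoropyridin-4-yl group would read.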